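The source may report more compounds than this note shows. Statements on the series, on what has been measured and on what is new or still open speak of the compounds shown alone.

In an assay on isolated protein for inhibition of annexin A2/S100-A10 (Homo sapiens), with a stated time of 5 min, tested at 50 uM (on this read-out lower numbers stand for less inhibition and higher numbers for more inhibition at the one concentration tested (going by the name of the read-out)), compound 1 `COCCCN1C(=O)C(O)=C(C(=O)c2ccc(C)cc2)C1c1ccc(C(C)C)cc1` gives 111%, compound 2 `C=CCN1C(=O)C(O)=C(C(=O)c2ccc(C)cc2)C1c1ccc(C(C)C)cc1` gives 105%, and compound 3 `COc1cccc(C(=O)C2=C(O)C(=O)N(CC(C)O)C2c2ccc(C(C)C)cc2)c1` gives 110%.

All three numbers lie within the usual scatter of one another, so compound 3 stands level with compound 1 and compound 2 in this assay. Within the data shown here, the one measured step, a number 6 percentage points lower from compound 1 to compound 2 (within the scatter), alters the chain on a saturated chain carbon bound to an amide-type nitrogen in a ring and stays within the scatter. Compound 4 `CC(O)CN1C(=O)C(O)=C(C(=O)c2ccc(Cl)cc2)C1c1ccc(C(C)C)cc1` differs from compound 3 in another place: 4-chlorophenyl in place of 3-methoxyphenyl on a carbonyl carbon. Among the measured compounds shown here, no measured step touches the group on the carbonyl carbon, so nothing here shows that such a swap moves the read-out, and the only change seen so far left it near its level. Compound 4 is therefore expected at 108%, between 95% and 120%, a step of a number 2 percentage points lower from compound 3 to compound 4 (within the scatter) that is estimated to remain within the scatter.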

Compound 4, a percentage reported as inhibition, at one concentration (the size of the read-out at that concentration, not a potency): 126%
Beside the measured number, compound 4's estimate is 18 percentage points below it; measured number above the stated range.
By their numbers in this assay, from the lowest: compounds 2, 3 and 1 (each within the scatter of the next); then compound 4.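

In this assay the group on the carbonyl carbon proves able to move the read-out: 4-chlorophenyl in place of 3-methoxyphenyl gives (a number 16 percentage points higher from compound 3 to compound 4 (beyond the scatter)), the first listed step beyond the scatter. Among these compounds, the only earlier step, at the chain on the amide-type nitrogen, stayed within it. Nothing measured here explains the rise.

Still open, on these data alone, is which part of the swap carries the step: gaining the chlorine, or losing the methoxy group. A plain phenyl or a 4-bromophenyl on that carbonyl carbon would bear on this.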